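The source may hold more compounds than are shown below. What is called first, only, known or untested is meant among the compounds shown, and "the series" means these compounds.

Measured so far in an ADME assay on THP-1 cells (Homo sapiens) for cytotoxicity, read by flow cytometry and propidium iodide staining, with a stated time of 72 h (on this read-out higher numbers stand for weaker inhibition and lower numbers for stronger inhibition), on this series
Compound 1 `Cn1cnc(CS(=O)(=O)c2ccc(Br)cc2)c1[N+](=O)[O-]` gives > 694000 nM (a limit, not a number)
Compound 2 `Cc1ccc(S(=O)(=O)Cc2nc(C)n(C)c2[N+](=O)[O-])cc1` gives 242000 nM
Compound 3 `Cc1nc(CS(=O)(=O)c2ccc(Cl)cc2)c([N+](=O)[O-])n1C` gives 68000 nM

Compound 3 stands lowest of the two actual numbers, at 68000 nM in this assay. Within the data shown here, the only measured step is a 3.6-fold lower number from compound 2 to compound 3 (0.55 log units; beyond the scatter), and it is modest. The entry for compound 1 is a limit, (the limit of > 694000 nM in this assay, at which 1 of the 3 values shown sits), and not a number.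

Next is compound 4 `Cc1nc(CS(=O)(=O)c2ccc(Br)cc2)c([N+](=O)[O-])n1C`, with one change from compound 3: bromo in place of chloro on an aromatic carbon. Among the measured compounds shown here, the modest step of a 3.6-fold lower number from compound 2 to compound 3 (0.55 log units; beyond the scatter) bears on this place and is the only guide to its size. Compound 1 also carries the 4-bromophenyl group on a different core, and its > 694000 nM is a limit. No step beyond the scatter is therefore expected in this assay, and no direction is favoured. The expected step is a 1.0-fold higher number from compound 3 to compound 4 (0.01 log units; within the scatter) and remains an estimate. For compound 4 the estimated value is 70000 nM, with an expected range of 30000 nM to 180000 nM and more room left on the upper side.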

Compound 4, half-maximal inhibitory concentration: 326000 nM
The estimate for compound 4 lay 4.7-fold (0.67 log units) below the measured number; the measured number lies above the stated range.
By their numbers in this assay, from the lowest: compound 3; then compounds 2 and 4 (each within the scatter of the next). At a limit, above all of these: compound 1.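

In this assay, the halogens at this place are not interchangeable: 4-chlorophenyl to 4-bromophenyl gives a 4.8-fold higher number from compound 3 to compound 4 (0.68 log units; beyond the scatter), while bromo in place of methyl gives a 1.3-fold higher number from compound 2 to compound 4 (0.13 log units; within the scatter), so on the shared core only the chloro compound stands apart from the other two. With the 4-bromophenyl group held fixed, methyl in place of hydrogen on an aromatic carbon of the core gives an at least 2.1-fold lower number from compound 1 to compound 4 (0.32 log units; beyond the scatter), which shows that this second place also counts. Compound 1 is a limit, not a number: the limit of > 694000 nM in this assay, at which 1 of the 4 values shown sits.

From the compounds shown here alone, how a fluoro, a methoxy or an amine at the same place on the six-membered ring would read against chloro and bromo stays open. Also open is whether the chloro-to-bromo step recurs on the core of compound 1, where only the bromo group is shown.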